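A few compounds are considered here, and "the series" means these few. Any claim that something is new, unique, unknown or untested is made for them only; others in the source may bear on it.

Measured so far:
Compound 1 `CN(C)CCC(OC(=O)c1cn(C)c2ccccc12)c1ccc(Cl)cc1`: 104%
Compound 2 `CN(C)CCC(OC(=O)c1ccc2ccccc2c1)c1ccc(Cl)cc1`: 49%
Compound 3 `CCc1ccccc1C(=O)OC(CCN(C)C)c1ccc(Cl)cc1`: 128%

In an assay on NIH3T3 cells with Urotensin-2 receptor (Homo sapiens) as the target (a lower number here means a smaller maximal response, a higher number a larger maximal response), compound 3 stands highest of the three numbers. Its nearest neighbour is compound 1, whose value lies lower by a margin beyond the usual scatter, and the furthest is compound 2, lower still by a wide margin. Compound 4 `Cc1c(Cl)cccc1C(=O)OC(CCN(C)C)c1ccc(Cl)cc1` keeps the shared core of compound 3 and differs from it by one change: 3-chloro-2-methylphenyl in place of 2-ethylphenyl on a carbonyl carbon. Among the measured compounds shown here, no step between two measured compounds matches this change, so the expected size of the step is uncertain. The estimate for compound 4 places it near compound 3, with a step of a number 13 percentage points lower from compound 3 to compound 4 (beyond the scatter) that is expected to stay within the scatter. Compound 4 is expected to give 115%, in a range from 85% to 145%.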

Compound 4, largest response reached (reported as efficacy), in percent of the reference or control that the assay uses: 118%
For compound 4 the middle estimate is 3 percentage points below the measured one; the range from low to high includes it.
By their numbers in this assay, from the lowest: compound 2; then compound 1; then compounds 4 and 3 (each within the scatter of the next).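

Among the compounds shown here, replacing 2-ethylphenyl with 3-chloro-2-methylphenyl on the carbonyl carbon in this assay gives a number 10 percentage points lower from compound 3 to compound 4 (within the scatter) and is the first step that can be read at this position. This position therefore tolerates this exchange of two groups with equal heavy-atom counts, with the maximal response staying within the scatter. Nothing available explains this result. Still open, on these data alone, is whether an amine or a carboxylic acid on this phenyl ring, or a longer chain in place of ethyl, would keep the response at this level.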